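A few compounds are considered here, and "the series" means these few. Any claim that something is new, unique, unknown or untested is made for them only; others in the source may bear on it.

Among the compounds with values here, compound 3 `COc1cc2c(Oc3ccc(NC(=O)c4cc(-c5ccc(C)cc5)nc5ccccc45)cc3F)ccnc2cc1OCCCN1CCC(C)CC1` gives 1260 nM in a functional assay on SMMC-7721 cells (Homo sapiens) for cytotoxicity, read by MTT assay, with a stated time of 72 h (a lower number here means a stronger inhibitor, a higher number a weaker inhibitor), the highest of the three numbers measured so far. Compound 2 `COc1cc2c(Oc3ccc(NC(=O)c4cc(-c5ccccc5)nc5ccccc45)cc3F)ccnc2cc1OCCCN1CCC(C)CC1` gives 160 nM, and compound 1 `COc1cc2c(Oc3ccc(NC(=O)c4cc(-c5cccc(Cl)c5)nc5ccccc45)cc3F)ccnc2cc1OCCCN1CCC(C)CC1` gives 80 nM. The step of a 2.0-fold higher number from compound 1 to compound 2 (0.30 log units; within the scatter) stays within the scatter, whereas a 7.9-fold higher number from compound 2 to compound 3 (0.90 log units; beyond the scatter) and a 16-fold higher number from compound 1 to compound 3 (1.20 log units; beyond the scatter) both lie beyond it. Compound 4 `COc1cc2c(Oc3ccc(NC(=O)c4cc(-c5ccc(C)cc5)nc5ccccc45)cc3F)ccnc2cc1OCCCN1CCCC1` differs from compound 3 at the end of the chain: pyrrolidin-1-yl in place of 4-methylpiperidin-1-yl on a saturated chain carbon, three bonds along the chain from an oxygen on an aromatic ring. Within the data shown here, none of the measured steps touches this part of the molecule; all three concern a different part of the shared core, so they offer no direct guide. A step no larger than the scatter is therefore expected, no change at the digits printed from compound 3 to compound 4 (within the scatter). Compound 4 is estimated at 1260 nM, between 500 nM and 3200 nM.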

Compound 4, half-maximal inhibitory concentration: 520 nM
For compound 4 the middle estimate is 2.4-fold (0.38 log units) above the measured one; the range from low to high includes it.
By their numbers in this assay, from the lowest: compounds 1 and 2 (each within the scatter of the next); then compound 4; then compound 3.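

The end of the chain also counts: in this assay, pyrrolidin-1-yl in place of 4-methylpiperidin-1-yl gives a 2.4-fold lower number from compound 3 to compound 4 (0.38 log units; beyond the scatter), so a change here can move the number, which steps elsewhere on the shared core could not show. The swap alters ring size and removes the methyl together, so this one step cannot separate the two. Nothing available explains the shift.

Going by these compounds, whether the step carries over to the parent compounds with other aryl groups, compound 1 and compound 2, stays open. So does what an unsubstituted piperidin-1-yl, a morpholin-4-yl or a longer chain would give.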